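The source may report more compounds than this note shows. Statements on the series, on what has been measured and on what is new or still open speak of the compounds shown alone.

Two measured members of the series share one core. Compound 1 `C/C(=N\NC(=O)COc1cccc2ccccc12)c1ccccc1Br` gives 79.8 ug/mL in an ADME assay on MT4 cells (Homo sapiens) for cytotoxicity, read by MTT assay, with a stated time of 4 days (on this read-out higher numbers stand for lower toxicity in this test and lower numbers for higher toxicity in this test), and compound 2 `O=C(COc1cccc2ccccc12)N/N=C/c1ccc([N+](=O)[O-])cc1` gives 87.9 ug/mL in this assay; the two numbers lie within the usual scatter of each other, so compound 2 stands level with compound 1 rather than apart from it. Compound 3 `Cc1ccc(/C=N/NC(=O)COc2cccc3ccccc23)cc1` is not yet measured. It differs from compound 2 by methyl in place of nitro on an aromatic carbon. For the measured compounds named here, with no measured step to draw on, the expected step in this assay is a 1.2-fold lower number from compound 2 to compound 3 (0.07 log units; within the scatter), essentially none beyond the scatter. Compound 3 is therefore estimated at 75 ug/mL, with a range from 40 ug/mL to 130 ug/mL.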

Compound 3, half-maximal cytotoxic concentration: 83.9 ug/mL
Beside the measured number, compound 3's estimate is 1.1-fold (0.05 log units) below it, within the range that was stated.
By their numbers in this assay, from the lowest: compounds 1, 3 and 2 (each within the scatter of the next).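

At this place, on an aromatic carbon para to a large group, methyl in place of nitro gives a 1.0-fold lower number from compound 2 to compound 3 (0.02 log units; within the scatter) in this assay. The read-out therefore stays level when nitro, with its hydrogen-bond acceptors, gives way to a group with none. No measurement here offers an explanation for this.

Still open, as far as these compounds go, is whether an amine, a carboxylic acid or a longer chain at this place would move the number beyond the scatter. Changes to the shared core also remain untested in these compounds.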